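A few compounds are considered here, and "the series" means these few. Any claim that something is new, unique, unknown or untested is made for them only; others in the source may bear on it.

Compound 1 `C[C@]1(CN2CCc3nc(-c4ccc(OC(F)(F)F)cc4)ccc3C2)Cn2cc([N+](=O)[O-])nc2O1`: in an ADME assay on Vero cells (Chlorocebus sabaeus) for cytotoxicity, read by MTT assay, with a stated time of 72 h (on this read-out higher numbers stand for lower toxicity in this test and lower numbers for higher toxicity in this test), compound 1 gives "not determined" (no result reported).
Compound 2 `C[C@]1(CN2CCc3oc(-c4ccc(F)cc4)nc3C2)Cn2cc([N+](=O)[O-])nc2O1`: in this assay compound 2 gives > 32 ug/mL, which is a limit of the assay and not a number.

Compound 1 stands nowhere on the numbers shown: it has no value of its own in this assay, and the one further value shown is the limit of > 32 ug/mL in this assay, at which 1 of the 2 values shown sits. Within the data shown here, compound 2 therefore offers only a floor, not a point, and no measured step between compound 1 and compound 2 exists, so the size of any change in this assay cannot be read from the data.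

Compound 3 `C[C@]1(CN2CCc3nc(-c4cc(F)ccc4F)ccc3C2)Cn2cc([N+](=O)[O-])nc2O1` is the unmeasured member. It differs from compound 1 by 2,5-difluorophenyl in place of 4-(trifluoromethoxy)phenyl on an aromatic carbon. Among the measured compounds shown here, with no measured step to lean on, the size of the move in this assay from compound 1 to compound 3 is unknown; the expectation is that the step lies within the usual scatter, in no particular direction, and that the result again sits at or near the limit at which compound 2 sits. Compound 3 is accordingly estimated at 40 ug/mL, with a range from 15 ug/mL to 128 ug/mL.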

Compound 3, half-maximal cytotoxic concentration: > 32 ug/mL
Compound 3: no number, only a limit (the forecaster's own chance of this, stated with the estimate: 70%); the middle value lies beyond the limit too.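

In this assay, among these compounds, compound 3 gives > 32 ug/mL, which is a limit of the assay and not a number, so no step from compound 1 to compound 3 can be read. The compounds shown leave open where the half-maximal cytotoxic concentration of any of them actually lies, and whether 2,5-difluorophenyl in place of 4-(trifluoromethoxy)phenyl alters it at all.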